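The source may hold more compounds than are shown below. What is called first, only, known or untested is meant among the compounds shown, and "the series" means these compounds.

Working notes on the ester series in a functional assay on HCT-15 cells (Homo sapiens) for antiproliferative activity, read by sulforhodamine B assay, with a stated time of 48 h, tested at 50 uM; on this read-out lower numbers stand for less inhibition and higher numbers for more inhibition at the one concentration tested (going by the name of the read-out).

Compound 1 `COc1ccc(C(=O)Oc2cc3c(cc2C)[C@@H](C(C)C)CC=C3C)cc1` stands highest of the two numbers in hand: in this assay compound 1 gives 30.8%. Its nearest neighbour by number is compound 3 `CC1=CC[C@H](C(C)C)c2cc(C)c(OC(=O)c3cccc(Cl)c3)cc21`, which in this assay gives 5.3%. Compound 2 `COc1cccc(C(=O)Oc2cc3c(cc2C)[C@@H](C(C)C)CC=C3C)c1` is reported in this assay as "not active" (no number reported), without a number.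

Within the data shown here, the one measured step that replaces the 4-methoxyphenyl group is a number 25.5 percentage points lower from compound 1 to compound 3 (beyond the scatter); that replacement brought 3-chlorophenyl in and lowered the read-out beyond the scatter. Compound 2 shows only that an isomeric methoxyphenyl ester has no reported activity.

Compound 4 `CC1=CC[C@H](C(C)C)c2cc(C)c(OC(=O)c3ccc(C(F)(F)F)cc3)cc21` differs from compound 1 as follows: trifluoromethyl in place of methoxy on an aromatic carbon. Among the measured compounds shown here, no measured step swaps one group for another at this aromatic carbon, so the step from compound 1 to compound 3 is the only guide, and it points downward. An estimated step of a number 15.8 percentage points lower from compound 1 to compound 4 (beyond the scatter) is therefore expected, direction downward, of modest size, with wide uncertainty since the step into compound 3 rests on a different change.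

For compound 4 the estimate in this assay is 15%, expected to lie between 0% and 38%.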

Compound 4, a percentage reported as inhibition, at one concentration (the size of the read-out at that concentration, not a potency): 6.4%
Compound 4: the middle estimate sits 8.6 percentage points above what was measured, and the stated range covers the measured number.
By their numbers in this assay, from the lowest: compounds 3 and 4 (each within the scatter of the next); then compound 1.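

In this assay, among these compounds, the step to compound 4 is the first measured change made at the methoxy-bearing aromatic carbon itself, para to a large group, with the rest of compound 1 unchanged: trifluoromethyl in place of methoxy gives a number 24.4 percentage points lower from compound 1 to compound 4 (beyond the scatter). Unlike the step to compound 3, which changes both the group and where it sits, this step ties the loss directly to replacing the methoxy at this place, although compound 2, an isomeric methoxyphenyl ester reported without a number, goes against any reading that methoxy alone is enough. No measurement shown here gives a reason for this drop.

The compounds shown leave open whether any other group at this aromatic carbon can match or exceed compound 1, since methoxy and trifluoromethyl are the only two groups compared directly here. An amine, a hydroxyl group, a carboxylic acid or a longer alkoxy chain such as ethoxy in the same place would show whether the read-out of compound 1 is specific to methoxy or is shared by other groups there.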